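The source may report more compounds than this note shows. Statements on the series, on what has been measured and on what is new or still open speak of the compounds shown alone.

Measured compounds:
compound 1 `O=C(Nc1cccc(-n2cc(-c3ccncc3)c(-c3cc(O)cc(Cl)c3)n2)c1)Nc1ccc(Cl)c(C(F)(F)F)c1` — 59.3% in a functional assay on OVCAR-5 cells (Homo sapiens) for inhibition, read by sulforhodamine B assay, with a stated time of 48 h, tested at 10 uM; on this read-out higher numbers stand for a weaker effect at the one concentration tested and lower numbers for a stronger effect
compound 2 `O=C(Nc1cccc(-n2cc(-c3ccncc3)c(-c3cc(O)cc(Cl)c3)n2)c1)Nc1ccc(Cl)c(Cl)c1` — -2.26% in this assay
compound 3 `COc1cc(Cl)cc(-c2nn(-c3cccc(NC(=O)Nc4cc(C(F)(F)F)cc(C(F)(F)F)c4)c3)cc2-c2ccncc2)c1` — 21.7% in this assay

Among the three numbers in this assay compound 2 gives the lowest, and the step of a number 61.6 percentage points lower from compound 1 to compound 2 (beyond the scatter) places it well beyond the scatter from compound 1. Compound 3 sits between, its value in this assay being higher than that of compound 2 by more than the scatter.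

Compound 4 `COc1cc(Cl)cc(-c2nn(-c3cccc(NC(=O)Nc4ccc(Cl)c(Cl)c4)c3)cc2-c2ccncc2)c1` is the next compound; it differs from compound 2 in a single place: methyl in place of hydrogen on an oxygen on an aromatic ring. Within the data shown here, the only measured step, a number 61.6 percentage points lower from compound 1 to compound 2 (beyond the scatter), concerns the urea side of the molecule and not the oxygen on the aromatic ring, so no measured step bears directly on this change. Compound 3 also carries the methoxy group but differs from compound 2 in a second place as well, so its value only hints that a methoxy compound can still show a clear effect in this assay. Among the measured compounds shown here, with no direct precedent, the step of a number 17.3 percentage points higher from compound 2 to compound 4 (beyond the scatter) is expected to be small, with a wide uncertainty. Compound 4 is therefore estimated at 15%, within -10% to 45%.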

Compound 4, a percentage reported as activity, at one concentration (the size of the read-out at that concentration, not a potency): 37.8%
Beside the measured number, compound 4's estimate is 22.8 percentage points below it; the measured number falls inside the stated range.
By their numbers in this assay, from the lowest: compound 2; then compound 3; then compound 4; then compound 1.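

In this assay, among these compounds, the step of a number 40.1 percentage points higher from compound 2 to compound 4 (beyond the scatter) is the first direct reading at the oxygen on the aromatic ring, and it shows that this position is not indifferent: with the rest of compound 2 unchanged, going from hydroxy to methoxy weakens the effect at the one concentration tested. Among the compounds shown here, until now, the only direct comparison concerned the urea side, through the step of a number 61.6 percentage points lower from compound 1 to compound 2 (beyond the scatter), so the series now has a change beyond the scatter at each of two separate places. Nothing measured here accounts for the effect of this added methyl.

Going by these compounds, the change from hydroxy to methoxy is read on this one pair only, so whether it weakens the effect to a similar extent with another group on the urea side stays open. Also open, on these data alone, is how this assay would respond to other replacements at this place, such as an amine, a carboxylic acid or a longer chain on the oxygen, which would show whether the free hydroxy itself is what matters or whether other groups can stand in for it.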